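Swapping Isopropyl for Bromophenyl: Expected Cytotoxicity

The compounds below may be only part of what the source reports. "The series", "measured", "known", "first", "only" and "open" are said of these compounds alone.

Measured compounds in an ADME assay on Huh-7 cells (Homo sapiens) for cytotoxicity; a lower number here means that less compound is tolerated, a higher number that more compound is tolerated:
Compound 1 `CN1CCN(CCNCc2cn(-c3ccc([N+](=O)[O-])cc3)nc2-c2ccc(C(F)(F)F)cc2)CC1` gives 3200 nM.
Compound 2 `Cc1ccccc1-c1nn(C(C)C)cc1CNCCN1CCN(C)CC1` gives only a limit, > 20000 nM.
Compound 3 `Cc1ccccc1-c1nn(-c2ccc(F)cc2F)cc1CN1CCC(N2CCCCC2)CC1` gives only a limit, > 20000 nM.

Compound 2 therefore stands at the upper edge of what this assay reports (the limit of > 20000 nM in this assay, at which 2 of the 3 values shown sit), and only compound 1 gives an actual number. Compound 4 `Cc1ccccc1-c1nn(-c2ccc(Br)cc2)cc1CNCCN1CCN(C)CC1` differs from compound 2 in one place: 4-bromophenyl in place of isopropyl on an aromatic nitrogen. Going by the values given here, no pair of measured compounds differs in a single place, so no measured step sets the scale for this change; the three values show that a compound of this family can either remain at the limit or be tolerated at a measurable level. Compound 4 is expected to sit near the limit, with an estimated step of an at least 1.6-fold lower number from compound 2 to compound 4 (0.22 log units; that floor lies within the scatter). For compound 4 the expected value is 12000 nM, in a range from 3000 nM to 30000 nM.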

Compound 4, half-maximal cytotoxic concentration: 9600 nM
Beside the measured number, compound 4's estimate is 1.3-fold (0.10 log units) above it; the range from low to high includes it.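

Going by these compounds alone, the change to 4-bromophenyl in place of isopropyl on an aromatic nitrogen gives an at least 2.0-fold lower number from compound 2 to compound 4 (0.31 log units; beyond the scatter) in this assay, the first single-place step here, and it shows that the group at this position can move the number beyond the scatter. Compound 2 gives only a limit, > 20000 nM, so this step is a floor and its full size remains unknown: the limit of > 20000 nM in this assay, at which 2 of the 4 values shown sit.

Whether the ring or the bromine accounts for the step stays open. Plain phenyl or a 4-chlorophenyl group on this nitrogen would help separate the two.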